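A few compounds are considered here, and "the series" means these few. Any claim that something is new, unique, unknown or untested is made for them only; others in the source may bear on it.

Measured compounds and their values:
compound 1 `O=S(=O)(NCCCCNCc1ccc(Br)cc1)c1cc(C(F)(F)F)cc(C(F)(F)F)c1`: 2900 nM
compound 2 `O=S(=O)(NCCCNCc1ccc(Cl)c(Cl)c1)c1cc(C(F)(F)F)cc(C(F)(F)F)c1`: 2800 nM

In a functional assay on ASPC1 cells (Homo sapiens) for inhibition, read by MTT assay, with a stated time of 72 h (on this read-out lower numbers stand for stronger inhibition of growth and higher numbers for weaker inhibition of growth), compound 1 gives 2900 nM. In the same assay compound 2 gives 2800 nM. On these two numbers compound 2 stands level with compound 1, since the step of a 1.0-fold lower number from compound 1 to compound 2 (0.02 log units; within the scatter) is within the scatter, so neither compound can be called the stronger of the pair.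

Compound 3 `O=S(=O)(NCCCNCC1COc2ccccc2O1)c1cc(C(F)(F)F)cc(C(F)(F)F)c1` has not yet been measured in this assay. It differs from compound 2 in one place: 2,3-dihydro-1,4-benzodioxin-2-yl in place of 3,4-dichlorophenyl on a saturated chain carbon bound to an amine nitrogen. Within the data shown here, the only measured step that bears on this change is a 1.0-fold lower number from compound 1 to compound 2 (0.02 log units; within the scatter), which exchanged one halogenated benzylamine for another on the same chain and moved the number by nothing beyond the scatter. Among the measured compounds shown here, no measured step shows what happens when the aromatic ring on that chain carbon is replaced by a group that carries a non-aromatic ring with two oxygen acceptors, so the expectation rests on thin ground and the range is kept wide.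

The expected step of a 1.3-fold higher number from compound 2 to compound 3 (0.10 log units; within the scatter) is therefore none beyond the scatter. Compound 3 is estimated at 3500 nM, with a range from 1200 nM to 12000 nM.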

Compound 3, concentration for 50% growth inhibition: 2900 nM
Estimate against measurement, compound 3: 1.2-fold (0.08 log units) above; the range from low to high includes it.
By their numbers in this assay, from the lowest: compounds 2, 1 and 3 (each within the scatter of the next).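

In this assay, 2,3-dihydro-1,4-benzodioxin-2-yl in place of 3,4-dichlorophenyl on a saturated chain carbon bound to an amine nitrogen gives a 1.0-fold higher number from compound 2 to compound 3 (0.02 log units; within the scatter), so compound 2 and compound 3 stand level. The earlier pair exchanged only one halogenated benzylamine for another, whereas this change removes both chlorine atoms and brings in a six-membered non-aromatic ring with two hetero atoms, along with hydrogen-bond acceptors where the leaving group has none, and the number still stays within the scatter. For these compounds, then, the chlorine atoms are not needed to hold the number at this level, though nothing available explains why it holds across so different a group.

The compounds shown leave open whether this tolerance extends to groups further from these two, such as a carboxylic acid on the benzyl ring, a morpholine or a plain cyclohexylmethyl in the same place. Among these compounds, they also leave open what a longer chain would do when the benzodioxin group is kept, since the chain and the halogen pattern vary together in the only step that touches the chain.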